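The source may hold more compounds than are shown below. What is called first, only, known or untested is meant among the compounds shown, and "the series" means these compounds.

Working notes on the series, read out in an ADME assay on BJ cells (Homo sapiens) for cytotoxicity, read by MTT assay, with a stated time of 72 h; on this read-out lower numbers stand for higher toxicity in this test and higher numbers for lower toxicity in this test:

- compound 1 `OC[C@H]1O[C@@H](n2cc(F)c3c(-c4ccc[nH]4)ncnc32)[C@H](O)[C@@H]1O`: 2990 nM
- compound 2 `OC[C@H]1O[C@@H](n2cc(F)c3c(-c4cc[nH]c4)ncnc32)[C@H](O)[C@@H]1O`: 2020 nM
- compound 3 `OC[C@H]1O[C@@H](n2cc(F)c3c(-c4nccs4)ncnc32)[C@H](O)[C@@H]1O`: 630 nM

Compound 3 has the lowest number of the three. The next structure is compound 4 `OC[C@H]1O[C@@H](n2cc(F)c3c(-c4c[nH]cn4)ncnc32)[C@H](O)[C@@H]1O`, and the change is 1H-imidazol-4-yl in place of 1,3-thiazol-2-yl on an aromatic carbon. Among the measured compounds shown here, two measured steps bear on it, and both ran into the 1,3-thiazol-2-yl group: a 4.7-fold lower number from compound 1 to compound 3 (0.68 log units; beyond the scatter) and a 3.2-fold lower number from compound 2 to compound 3 (0.51 log units; beyond the scatter). Both are modest but beyond the scatter. Moving between the two pyrrolyl groups mattered little, with a 1.5-fold lower number from compound 1 to compound 2 (0.17 log units; within the scatter). For the measured compounds named here, the 1H-imidazol-4-yl group is a 1H ring like those pyrrolyl groups, but no imidazolyl compound has been measured, so a partial reversal is expected in this assay. The expected change is a 2.5-fold higher number from compound 3 to compound 4 (0.40 log units; beyond the scatter), towards a higher number. For compound 4 the estimate is 1600 nM, with a range of 600 nM to 4500 nM.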

Compound 4, half-maximal cytotoxic concentration: > 50000 nM
Compound 4 gave a limit, no number (the forecaster's own chance of this, stated with the estimate: 2%); at least 31-fold (1.49 log units) between middle value and limit.
By their numbers in this assay, from the lowest: compound 3; then compounds 2 and 1 (each within the scatter of the next). At a limit, above all of these: compound 4.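

In this assay, compound 4 gives a limit and no number: the limit of > 50000 nM in this assay, at which 1 of the 4 values shown sits. The step is an at least 79-fold higher number from compound 3 to compound 4 (1.89 log units; beyond the scatter), and against the two pyrrolyl groups it is an at least 24-fold higher number from compound 2 to compound 4 (1.39 log units; beyond the scatter) and an at least 16-fold higher number from compound 1 to compound 4 (1.22 log units; beyond the scatter). Among the compounds shown here, the position therefore allows a far wider spread than the earlier compounds showed, even between five-membered aromatic rings with 2 hetero atoms and the same count of heavy atoms.

On these data alone, whether a 1H-pyrazol-4-yl group or a 1H-imidazol-2-yl group would behave like 1H-imidazol-4-yl stays open. As far as these compounds go, an amine on this carbon is equally open.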